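Two Methoxyphenyl Groups on the Same Carbonyl Carbon

A few compounds are considered here, and "the series" means these few. Any claim that something is new, unique, unknown or untested is made for them only; others in the source may bear on it.

Measured so far:
compound 1, `CO[C@@H]1OC[C@@H](OC(C)=O)[C@@H](OC(C)=O)[C@]1(F)n1ccc(=O)[nH]c1=O`: 55000 nM
compound 2, `COc1ccccc1C(=O)/C=C/c1cc(=O)[nH]c(=O)n1COCCO`: 15200 nM

Both compounds have been run in an ADME assay on L1210/0 cells (Mus musculus) for cytotoxicity, with a stated time of 48 h; on this read-out higher numbers stand for weaker inhibition and lower numbers for stronger inhibition. Compound 1 gives 55000 nM, while compound 2 gives 15200 nM. Of the two numbers, compound 2 holds the lower one, and compound 1 sits a clear step higher, beyond the usual scatter, so compound 2 is the stronger inhibitor of this pair in this assay.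

Compound 3, `COc1ccc(C(=O)/C=C/c2cc(=O)[nH]c(=O)n2COCCO)cc1`, is still to be measured. It contains exactly the same atoms as compound 2, joined differently: 4-methoxyphenyl in place of 2-methoxyphenyl on a carbonyl carbon

For the measured compounds named here, no measured pair in this small set shows the effect of such a rearrangement, so there is no comparable step to lean on. The change is modest on paper, and the counts of donors and acceptors are unchanged. For compound 3 the expected step of a 1.0-fold lower number from compound 2 to compound 3 (0.01 log units; within the scatter) is none beyond the scatter, in either direction. Compound 3 is therefore estimated at 15000 nM, within a range of 5000 nM to 45000 nM.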

Compound 3, half-maximal inhibitory concentration: 33500 nM
The estimate for compound 3 lay 2.2-fold (0.35 log units) below the measured number; the measured number falls inside the stated range.
By their numbers in this assay, from the lowest: compound 2; then compounds 3 and 1 (each within the scatter of the next).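

In this assay, for the compounds shown here, the swap of 4-methoxyphenyl in place of 2-methoxyphenyl on a carbonyl carbon gives a 2.2-fold higher number from compound 2 to compound 3 (0.34 log units; beyond the scatter) and is the first change here that can be read on its own, since compound 1 and compound 2 differ in more than one place. It shows that this position responds to where the methoxy group sits on the phenyl ring, even with the same atoms and unchanged counts of donors and acceptors, and that 2-methoxyphenyl goes with the lower number, which here means stronger inhibition, though the step is modest. The compounds shown offer no separate measurement that would explain the difference between these two groups.

On these data alone, what remains open is how 3-methoxyphenyl or plain phenyl on the same carbonyl carbon would compare with these two groups. As far as these compounds go, it is also open whether this preference holds for a different group on the phenyl ring, such as an amine, a carboxylic acid or a longer chain ending in an ether, since one pair cannot show how far it extends.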